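Swapping the Amino Group for Chloro on the Shared Core

The source may hold more compounds than are shown below. What is called first, only, known or untested is meant among the compounds shown, and "the series" means these compounds.

The series rests on a shared core carrying a chloromethyl-substituted benzyl group. Compound 1 `ClCc1ccc(Cn2cnc3c(Cl)ncnc32)cc1` is the parent; in a functional assay on OVCAR-3 cells (Homo sapiens) for cytotoxicity, read by sulforhodamine B assay, with a stated time of 48 h (a lower number here means a stronger inhibitor of growth, a higher number a weaker inhibitor of growth), compound 1 gives 1380 nM. Compound 2 `Nc1nc(Cl)c2ncn(Cc3ccc(CCl)cc3)c2n1` adds an amino group on an aromatic carbon of that core, and in this assay compound 2 gives 2140 nM. The move from the parent is small: a 1.6-fold higher number from compound 1 to compound 2 (0.19 log units; within the scatter). Among the measured compounds shown here, compound 2 thus holds the highest of the two numbers so far, with compound 1 nearest and within the scatter.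

Compound 3 `ClCc1ccc(Cn2cnc3c(Cl)nc(Cl)nc32)cc1` is not yet measured. It differs from compound 2 by chloro in place of amino on an aromatic carbon. For the measured compounds named here, only one measured step touches this position, the step from compound 1 to compound 2, and it stayed within the scatter. Going by the values given here, no measured step shows what a chloro group in this place does. The expectation for this assay is therefore a step of modest size, if any, with the direction uncertain; the estimated step is a 1.4-fold lower number from compound 2 to compound 3 (0.15 log units; within the scatter). Compound 3 is expected to give about 1500 nM, within a range from 500 nM to 4500 nM.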

Compound 3, concentration for 50% growth inhibition: 2000 nM
For compound 3 the middle estimate is 1.3-fold (0.12 log units) below the measured one; measured number inside the range.
By their numbers in this assay, from the lowest: compounds 1, 3 and 2 (each within the scatter of the next).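

At the aromatic carbon between two ring nitrogen atoms, the series now shows three substituents, hydrogen, amino and chloro, and in this assay the exchange of amino for chloro gives a 1.1-fold lower number from compound 2 to compound 3 (0.03 log units; within the scatter). Set against the parent, chloro in place of hydrogen gives a 1.4-fold higher number from compound 1 to compound 3 (0.16 log units; within the scatter), so chloro, like amino before it, leaves the read-out within the scatter of the other compounds. The three compounds therefore do not separate at this position, although amino and chloro differ in their counts of hydrogen-bond donors and acceptors, and no measurement here offers an explanation for this result.

The compounds shown leave open whether the read-out would also stay within the scatter with a methoxy group, a dimethylamino group or a carboxylic acid on this aromatic carbon. They also leave open what part the chloromethyl group plays in the growth inhibition, as all three compounds carry it and none has a hydroxymethyl or a plain methyl group in its place.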